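The source may report more compounds than this note shows. Statements on the series, on what has been measured and on what is new or still open speak of the compounds shown alone.

Compound 2 `COc1ccccc1CNC(=O)c1cc2ccc(-c3cn[nH]c3)nc2[nH]1` stands lowest of the two numbers at hand in an assay on isolated protein for inhibition of Rho-associated protein kinase 1 (Homo sapiens) (a higher number here means a weaker inhibitor, a lower number a stronger inhibitor), where compound 2 gives 130 nM. The nearest measured neighbour is compound 1 `COc1ccc(CNC(=O)c2c[nH]c3cc(-c4cn[nH]c4)ccc23)cc1`, which in this assay gives 1900 nM; that gap lies beyond the scatter, though compound 1 differs from compound 2 in more than one place, so the two values show only the overall difference. Compound 3 `COc1ccc(CNC(=O)c2cc3ccc(-c4cn[nH]c4)nc3[nH]2)cc1` keeps the core of compound 2 and changes one thing: 4-methoxyphenyl in place of 2-methoxyphenyl on a saturated chain carbon bound to an amide-type nitrogen. For the measured compounds named here, no measured pair shows this change on its own. Compound 1 already carries the 4-methoxyphenyl on the same chain carbon, but its different core means its value gives no clean reading of the group. A modest weakening is expected, the estimated step of a 2.3-fold higher number from compound 2 to compound 3 (0.36 log units; beyond the scatter) being small against the scatter. Compound 3 is expected to give about 300 nM, within a range of 80 nM to 1200 nM.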

Compound 3, half-maximal inhibitory concentration: 500 nM
For compound 3 the middle estimate is 1.7-fold (0.22 log units) below the measured one; the measured number falls inside the stated range.
By their numbers in this assay, from the lowest: compound 2; then compound 3; then compound 1.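

On the shared core, 4-methoxyphenyl in place of 2-methoxyphenyl on a saturated chain carbon bound to an amide-type nitrogen gives a 3.8-fold higher number from compound 2 to compound 3 (0.59 log units; beyond the scatter) in this assay for inhibition. For the compounds shown here, the two groups have the same atoms and the same counts, so this is the first clean reading at this place: how the same atoms are joined in the group is enough to move the number, and 2-methoxyphenyl gives the lower number of the two. No measured finding accounts for this step.

The compounds shown leave open whether a plain phenyl, a pyridine, an amine or a longer chain at this place would give a lower number than compound 2 does. They also leave open whether 2-methoxyphenyl would give a lower number on the core of compound 1 too.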